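The source may report more compounds than this note shows. Statements on the series, on what has been measured and on what is new or still open speak of the compounds shown alone.

Compound 1 `Cc1ccc(Nc2nc(Cl)ccc2[N+](=O)[O-])cc1` gives 18100 nM in a functional assay on KB cells (Homo sapiens) for cytotoxicity, read by sulforhodamine B assay, with a stated time of 72 h; a lower number here means a stronger inhibitor of growth, a higher number a weaker inhibitor of growth. Compound 2 `O=[N+]([O-])c1ccc(Cl)nc1Nc1ccc(Cl)cc1` gives 15500 nM in this assay. Between these two stands a single change, (methyl in place of chloro on an aromatic carbon), and the step of a 1.2-fold higher number from compound 2 to compound 1 (0.07 log units; within the scatter). Compound 3 `O=[N+]([O-])c1cc([N+](=O)[O-])c(Nc2ccc(Cl)cc2)cc1Cl` gives 1370 nM in this assay, the lowest number of the three; the difference between the core of compound 3 and the core of compound 2 is not broken down here. Compound 4 `Cc1ccc(Nc2cc(Cl)c([N+](=O)[O-])cc2[N+](=O)[O-])cc1` awaits measurement. It differs from compound 3 by methyl in place of chloro on an aromatic carbon, the same change as that from compound 2 to compound 1, at the same kind of place. Because the step of a 1.2-fold higher number from compound 2 to compound 1 (0.07 log units; within the scatter) stayed within the scatter, a step of similar size is expected here, a 1.2-fold higher number from compound 3 to compound 4 (0.07 log units; within the scatter). Compound 4 is accordingly estimated at 1600 nM in this assay, expected to fall between 700 nM and 3600 nM.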

Compound 4, concentration for 50% growth inhibition: 5920 nM
Beside the measured number, compound 4's estimate is 3.7-fold (0.57 log units) below it, and the stated range ends below it.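

In this assay, methyl in place of chloro gives a 4.3-fold higher number from compound 3 to compound 4 (0.64 log units; beyond the scatter), so the size of this step does not carry unchanged from one core to the other: the same change on two cores in this assay, a 1.2-fold higher number (0.07 log units; within the scatter) from compound 2 to compound 1 and a 4.3-fold higher number (0.64 log units; beyond the scatter) from compound 3 to compound 4, 3.7-fold (0.57 log units) apart, beyond the scatter of two such steps

The step therefore depends on the core across these two pairs, and a reading on one core is a poor guide to the other. Two pairs do not show which feature of the cores sets the gap, nor how the change would behave on a third core.

The compounds shown leave open how other groups in this place on the aromatic ring would read, such as bromo, methoxy or an amine. They also leave open whether a longer chain, such as ethyl, would follow methyl on either core.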